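The source may report more compounds than this note shows. Statements on the series, on what has been measured and on what is new or still open speak of the compounds shown alone.

Measured so far in a functional assay on TSU-Pr1 cells for antiproliferative activity against TSU (Homo sapiens), read by sulforhodamine B assay; on this read-out lower numbers stand for stronger inhibition and higher numbers for weaker inhibition:
compound 1, `CCCCCCCCCCCCCCCCCCNC(=O)[C@H]1CSC(c2ccc(N(C)C)cc2)N1`: 3000 nM
compound 2, `CCCCCCCCCCCCCCCCCCNC(=O)[C@H]1CSC(c2ccc(C#N)cc2)N1`: > 20000 nM

Compound 2 stands at the edge of what the assay reports: the value > 20000 nM for compound 2 is a limit, not a number, as recorded in the limit of > 20000 nM in this assay, at which 1 of the 2 values shown sits. Among the measured compounds shown here, compound 1 gives a number, so the one measured step, cyano in place of dimethylamino on an aromatic carbon, is a step from compound 1 to compound 2 of an at least 6.6-fold higher number from compound 1 to compound 2 (0.82 log units; beyond the scatter), and its true size is known only as a bound.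

Compound 3, `CCCCCCCCCCCCCCCCCCNC(=O)[C@H]1CSC(c2ccc(C)cc2)N1`, has not been measured in this assay. It differs from compound 2 by methyl in place of cyano on an aromatic carbon. For the measured compounds named here, the only measured step bearing on it is the one from compound 1 to compound 2, of an at least 6.6-fold higher number from compound 1 to compound 2 (0.82 log units; beyond the scatter), which shows the group at this carbon matters; methyl is a third group there, and neither measured result fixes where it lands. Compound 3 is expected to sit between the two measured outcomes, estimated at 8000 nM with a range of 2500 nM to 25000 nM. The estimated step of an at least 2.5-fold lower number from compound 2 to compound 3 (0.39 log units; beyond the scatter) is expected to run toward a lower number, though a limit may again be all that is returned.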

Compound 3, half-maximal inhibitory concentration: 8000 nM
Compound 3: middle estimate and measured number agree at the digits printed; the range from low to high includes it.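

In this assay, among the compounds shown here, methyl in place of dimethylamino on the aromatic carbon gives a 2.7-fold higher number from compound 1 to compound 3 (0.43 log units; beyond the scatter), the first step at this position with a number at both ends. Methyl in place of cyano gives an at least 2.5-fold lower number from compound 2 to compound 3 (0.39 log units; beyond the scatter), so the three groups now fall in the order dimethylamino, methyl, cyano from lower to higher number, with no compound shown going against that order and with the size of this second step known only as a bound. Compound 2 carries a limit and not a number: the limit of > 20000 nM in this assay, at which 1 of the 3 values shown sits.

As far as these compounds go, it remains open how far compound 2 truly lies from compound 3, and whether the order of the three groups extends to others on the same carbon, such as a primary amine, a methoxy group or a carboxylic acid. The compounds shown also all share the long chain on the amide, so what a shorter chain would do to any of these steps remains open.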